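Iodo in place of furan-3-yl at the assay limit

This account rests on a few compounds, and the source may have more. Where it says the series, first, only, none or still open, it means among the compounds named here.

In a functional assay on HCT-116 cells (Homo sapiens), read by MTT assay, with a stated time of 72 h (a higher number here means a weaker inhibitor, a lower number a stronger inhibitor), compound 1 (`CN(C)c1ncnc2c1c(-c1ccoc1)cn2[C@@H]1O[C@H](CO)[C@@H](O)[C@H]1O`) gives > 20000 nM as a limit of the assay. Compound 2 (`Cc1ncnc2c1c(-c1ccoc1)cn2[C@@H]1O[C@H](CO)[C@@H](O)[C@H]1O`) gives > 20000 nM as a limit too, not a number. Both compounds stand at the limit of > 20000 nM in this assay, at which 2 of the 2 values shown sit, and neither has a readable potency. Compound 3 (`Cc1ncnc2c1c(I)cn2[C@@H]1O[C@H](CO)[C@@H](O)[C@H]1O`) follows from compound 2 by the change iodo in place of furan-3-yl on an aromatic carbon with the rest of the structure kept. Going by the values given here, the one measured step that the two limits leave unreadable from compound 1 to compound 2 gives no size and concerns methyl in place of dimethylamino, so it offers no guide to this change. With compound 2 resting on the limit > 20000 nM in this assay only a move towards stronger inhibition could be read. The expected step of an at least 2.0-fold lower number from compound 2 to compound 3 (0.30 log units; that floor lies within the scatter) is therefore a modest, loosely held estimate in that direction. For compound 3 the estimate is 10000 nM with an expected range from 1500 nM to 20000 nM and a return to the limit remains quite possible.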

Compound 3, half-maximal inhibitory concentration: 7570 nM
Beside the measured number, compound 3's estimate is 1.3-fold (0.12 log units) above it; low and high end bracket the measured number.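

In this assay, iodo in place of furan-3-yl on an aromatic carbon gives an at least 2.6-fold lower number from compound 2 to compound 3 (0.42 log units; beyond the scatter), so this position, two ring bonds from the ring nitrogen, can move the read-out off the limit with the rest of the structure kept. The value of compound 2, > 20000 nM, is a limit and not a number, which makes the step a floor and leaves its full size unknown. Before compound 3, no step in the series could be read: the limit of > 20000 nM in this assay, at which 2 of the 3 values shown sit.

Going by these compounds, it remains open whether the gain belongs to iodo itself or to the loss of furan-3-yl, a question that chloro, bromo, a nitrile or a short alkyl chain at this carbon would address. Also open, on these data alone, is whether iodo acts the same way with dimethylamino in place of methyl, as in compound 1.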